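Amine-substituent variation in a chalcone series

The source may report more compounds than this note shows. Statements on the series, on what has been measured and on what is new or still open speak of the compounds shown alone.

Measured compounds:
compound 1, `CCN(CCCCOc1ccc(C(=O)/C=C/c2ccc(N(C)C)cc2)c(O)c1)Cc1ccccc1`: 77300 nM
compound 2, `CCN(CCCCOc1ccc(/C=C/C(=O)c2ccc(N(C)C)cc2O)cc1)Cc1ccccc1N(C)C`: 12300 nM
compound 3, `CCN(CC)CCCOc1ccc(C(=O)/C=C/c2ccc(N(C)C)cc2)c(O)c1`: 47100 nM

In an assay on isolated protein for inhibition of Amine oxidase [flavin-containing] A (Homo sapiens) (a lower number here means a stronger inhibitor, a higher number a weaker inhibitor), compound 3 gives 47100 nM, the second highest of the three numbers. Its nearest neighbour is compound 1, and that pair is connected by one step: a 1.6-fold lower number from compound 1 to compound 3 (0.22 log units; within the scatter). Compound 2 sits furthest away, with a number beyond the scatter below that of compound 3, but compound 2 differs from compound 3 in several places at once, so no single step can be read from it.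

Compound 4, `CCN(CCCOc1ccc(C(=O)/C=C/c2ccc(N(C)C)cc2)c(O)c1)Cc1ccc(N(C)C)cc1`, has not yet been measured. It differs from compound 3 in one place: 4-(dimethylamino)phenyl in place of methyl on a saturated chain carbon bound to an amine nitrogen

Going by the values given here, the only measured step at a comparable site is the one from compound 1 to compound 3, a change of the amine substituent that stayed within the scatter. Among the compounds with values here, that is the sole direct guide; the lower number of compound 2 carries a related group but cannot be attributed to it. On this basis the expected step is a 1.3-fold lower number from compound 3 to compound 4 (0.13 log units; within the scatter), that is, none beyond the scatter, with a lean toward a lower number only as a loose possibility. For compound 4 the estimate in this assay is 35000 nM, with a range from 10000 nM to 110000 nM.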

Compound 4, half-maximal inhibitory concentration: 57500 nM
For compound 4 the middle estimate is 1.6-fold (0.22 log units) below the measured one; measured number inside the range.
By their numbers in this assay, from the lowest: compound 2; then compounds 3, 4 and 1 (each within the scatter of the next).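

In this assay the exchange of methyl for 4-(dimethylamino)phenyl on a saturated chain carbon bound to an amine nitrogen gives a 1.2-fold higher number from compound 3 to compound 4 (0.09 log units; within the scatter) even though the entering group has 9 heavy atoms against the single carbon it replaces, and it also brings an aromatic ring and a hydrogen-bond acceptor. Read with a 1.6-fold lower number from compound 1 to compound 3 (0.22 log units; within the scatter) this makes two single-place changes of the amine substituent, and neither separates its pair of compounds, so in compounds 1, 3 and 4 the number does not follow the size of this substituent; compound 2 differs in several places and cannot be set against this pattern. No supporting data bear on this result, and the insensitivity at this position stays a plain observation.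

Going by these compounds, whether a carboxylic acid or a morpholine on the same chain carbon would move the number beyond the scatter remains open. Also open, on these data alone, is whether the number of compound 2 belongs to its amine substituent or to its other differences from compound 3, a question that a single-place partner of compound 2 would settle.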